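The source may hold more compounds than are shown below. What is called first, only, known or untested is meant among the compounds shown, and "the series" means these compounds.

Measured compounds in an in vitro functional assay on HEK285-7 cells for antagonist activity at prostaglandin D2 receptor 2 (Homo sapiens), read by BRET and beta-arrestin recruitment; a lower number here means a stronger inhibitor, a higher number a weaker inhibitor:
compound 1 `O=C(O)Cc1sc(C2COc3ccccc3O2)nc1-c1ccc(Cl)cc1`: 2000 nM
compound 2 `O=C(O)Cc1sc(C(c2ccccc2)c2ccc(F)c(F)c2)nc1-c1ccc(F)cc1`: 64 nM
compound 3 `O=C(O)Cc1sc(C(c2ccc(F)cc2)c2ccc(F)cc2)nc1-c1cn[nH]c1`: 220 nM

Compound 3 stands second highest of the three numbers in this assay; compound 2 lies beyond the scatter below it and compound 1 beyond the scatter above it. Compound 4 `O=C(O)Cc1sc(C(c2ccc(F)cc2)c2ccc(F)cc2)nc1-c1ccnc(N2CCC2)c1` is not yet measured. It differs from compound 3 in one place: 2-(azetidin-1-yl)pyridin-4-yl in place of 1H-pyrazol-4-yl on an aromatic carbon. Within the data shown here, no pair of measured compounds isolates this change, so the step is judged from the spread of the series alone. Compound 2 gives 64 nM, which marks the lower end of the range so far. A step from compound 3 to compound 4 toward a lower number, of moderate size and beyond the scatter, is expected. For compound 4 the estimate in this assay is 90 nM, with a range of 30 nM to 300 nM, corresponding to an expected step of a 2.4-fold lower number from compound 3 to compound 4 (0.39 log units; beyond the scatter).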

Compound 4, half-maximal inhibitory concentration: > 100000 nM
Compound 4: a limit, no number (the forecaster's own chance of this, stated with the estimate: 2%); middle value at least 1100-fold (3.04 log units) from the limit.
By their numbers in this assay, from the lowest: compound 2; then compound 3; then compound 1. At a limit, above all of these: compound 4.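

In this assay compound 4 gives > 100000 nM, a limit of the assay and not a number. With the rest of the structure unchanged, this position, on the aromatic carbon next to the ring nitrogen, proves highly sensitive to the group it carries: replacing 1H-pyrazol-4-yl with 2-(azetidin-1-yl)pyridin-4-yl gives an at least 450-fold higher number from compound 3 to compound 4 (2.65 log units; beyond the scatter).

Going by these compounds, whether the loss follows the six-membered aromatic ring or the four-membered ring on it stays open. Plain pyridin-4-yl and a pyridine carrying a dimethylamino group would separate the two.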